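A few compounds are considered here, and "the series" means these few. Any claim that something is new, unique, unknown or untested is made for them only; others in the source may bear on it.

Measured so far:
compound 1 `CCc1ccccc1-n1nncc1CN1C(=O)C2(C(C#N)=C(N)Oc3c(N)cc4nc5ccccc5nc4c32)c2ccccc21` — 22900 nM
compound 2 `N#CC1=C(N)Oc2c(N)cc3nc4ccccc4nc3c2C12C(=O)N(Cc1cnnn1-c1cc(Cl)ccc1Cl)c1ccccc12` — > 50000 nM (a limit)

In an ADME assay on L02 cells (Homo sapiens) for antiproliferative activity, read by MTT assay, with a stated time of 48 h (on this read-out lower numbers stand for stronger inhibition and higher numbers for weaker inhibition), compound 1 gives 22900 nM. For compound 2 the read-out is a limit of the assay, > 50000 nM. Compound 2 therefore stands at the weak end of the two numbers shown, and its place is fixed only by that limit. Among the compounds with values here, the single measured step, an at least 2.1-fold higher number from compound 1 to compound 2 (0.33 log units; beyond the scatter), runs toward weaker inhibition and ends at the limit (the limit of > 50000 nM in this assay, at which 1 of the 2 values shown sits), so its true size is open.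

Compound 3 `N#CC1=C(N)Oc2c(N)cc3nc4ccccc4nc3c2C12C(=O)N(Cc1cnnn1-c1c(Cl)cc(Cl)cc1Cl)c1ccccc12` differs from compound 2 by 2,4,6-trichlorophenyl in place of 2,5-dichlorophenyl on an aromatic nitrogen. Within the data shown here, the only measured step concerns the same position, where a 2-ethylphenyl gave way to a 2,5-dichlorophenyl; no measured step covers the move from 2,5-dichlorophenyl to 2,4,6-trichlorophenyl. With compound 2 already at the limit, compound 3 is expected in this assay to stay at or beyond it, with no step beyond the scatter in either direction being inferable. The implied step, a step that the limit leaves unreadable from compound 2 to compound 3, is estimated as not exceeding the scatter. Compound 3 is estimated at 60000 nM, within 30000 nM to 150000 nM.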

Compound 3, half-maximal inhibitory concentration: > 50000 nM
Compound 3 gave a limit, no number; the forecaster's own chance of this, stated with the estimate: 75%; the middle value lies beyond the limit too.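

In this assay compound 3 gives > 50000 nM, which is a limit of the assay and not a number. With 2,4,6-trichlorophenyl in place of 2-ethylphenyl on the aromatic nitrogen, the series shows an at least 2.1-fold higher number from compound 1 to compound 3 (0.33 log units; beyond the scatter), so a second chlorinated phenyl now ends on the weaker side of the only number in the set, and no compound shown goes against this. The step from compound 2 to compound 3 cannot be read, and the true size of both steps from the 2-ethylphenyl compound stays open: the limit of > 50000 nM in this assay, at which 2 of the 3 values shown sit.

The compounds shown leave open whether an unsubstituted phenyl, or a phenyl carrying a methoxy group or an amine, would give a readable number in this assay, and whether that number would lie on either side of compound 1 at 22900 nM. As far as these compounds go, it also remains unknown whether the change from 2,5-dichlorophenyl to 2,4,6-trichlorophenyl has any effect on this read-out, as neither compound gives a number.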